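Swapping Quinolin-2-yl for 2-Sulfoethyl on the Ether Chain

A few compounds are considered here, and "the series" means these few. Any claim that something is new, unique, unknown or untested is made for them only; others in the source may bear on it.

Three compounds share a core carrying two tert-butyl groups and a hydroxyl on one aryl ring, with an oxygen substituent on the other. Compound 1 `CC(C)(C)c1cc(-c2cc(=O)c3ccc(OCC(=O)N4CCCCC4)cc3o2)cc(C(C)(C)C)c1O` gives 3000 nM in a functional assay for inhibition; a lower number here means a stronger inhibitor, a higher number a weaker inhibitor. Compound 2 `COc1ccc2c(=O)cc(-c3cc(C(C)(C)C)c(O)c(C(C)(C)C)c3)oc2c1` gives 1000 nM in this assay, and compound 3 `CC(C)(C)c1cc(-c2cc(=O)c3ccc(OCc4ccc5ccccc5n4)cc3o2)cc(C(C)(C)C)c1O` gives 3000 nM in this assay. Compound 3 therefore stands level with compound 1, the two together holding the highest numbers of the three, while compound 2 sits lowest, with a 3.0-fold higher number from compound 2 to compound 3 (0.48 log units; beyond the scatter).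

Compound 4 `CC(C)(C)c1cc(-c2cc(=O)c3ccc(OCCCS(=O)(=O)O)cc3o2)cc(C(C)(C)C)c1O` differs from compound 3 by 2-sulfoethyl in place of quinolin-2-yl on a saturated chain carbon bound to an oxygen on an aromatic ring. For the measured compounds named here, two measured steps touch this position: no change at the digits printed from compound 1 to compound 3 (within the scatter) and a 3.0-fold higher number from compound 2 to compound 3 (0.48 log units; beyond the scatter). Replacing one bulky group with another left the number unchanged, whereas reducing the substituent to hydrogen lowered it modestly. The 2-sulfoethyl group is smaller than quinolin-2-yl, yet nothing measured resembles it, so only a small movement toward the value of compound 2 is expected, with a 1.5-fold lower number from compound 3 to compound 4 (0.18 log units; within the scatter) judged within or near the scatter. Compound 4 is thus estimated at 2000 nM in this assay, with a range of 700 nM to 6000 nM.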

Compound 4, half-maximal inhibitory concentration: 500 nM
Beside the measured number, compound 4's estimate is 4.0-fold (0.60 log units) above it, outside the stated range (below it).
By their numbers in this assay, from the lowest: compounds 4 and 2 (each within the scatter of the next); then compounds 1 and 3 (each within the scatter of the next).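

In this assay, the position on a saturated chain carbon bound to an oxygen on an aromatic ring turns out to take a substituent other than hydrogen with no rise in the number, which compounds 1 and 3 had not shown. Exchanging quinolin-2-yl for 2-sulfoethyl gives a 6.0-fold lower number from compound 3 to compound 4 (0.78 log units; beyond the scatter) and exchanging the (piperidin-1-yl)carbonyl group for it gives a 6.0-fold lower number from compound 1 to compound 4 (0.78 log units; beyond the scatter), so the level numbers of compounds 1 and 3 do not hold for every group placed here, while adding it in place of hydrogen gives a 2.0-fold lower number from compound 2 to compound 4 (0.30 log units; within the scatter) and leaves the two compounds indistinguishable in this measurement. The account offers no measured information on why 2-sulfoethyl parts from the two larger groups in this way.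

Whether the lower number goes with the sulfo group itself or with the open chain that carries it remains unsettled, and a plain propyl ether would speak to that directly. Equally open, from the compounds shown here alone, is what a carboxylic acid or an amine at the end of the same chain would give, and how a shorter or longer chain bearing the sulfo group would compare.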